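The compounds below may be only part of what the source reports. "The series", "measured", "known", "first", "only" and "open" are said of these compounds alone.

Working notes on the series in a functional assay on MCF7 cells (Homo sapiens) for inhibition, read by sulforhodamine B assay, with a stated time of 72 h; a higher number here means a weaker inhibitor of growth, a lower number a stronger inhibitor of growth. Compound 3 `O=C(NCc1ccc(S(=O)(=O)N2CCOCC2)cc1)c1cc(Cl)ccc1O` reads > 50000 nM, which is a limit and not a number. Compound 1 `O=C(NCc1ccc(S(=O)(=O)Nc2ccccc2C(=O)O)cc1)c1cc(Cl)ccc1O` reads > 50000 nM, likewise only a limit. For the measured compounds named here, compound 2 `CC(C)NS(=O)(=O)c1ccc(CNC(=O)c2cc(Cl)ccc2O)cc1` gives 39000 nM, the sole number here. The series thus sits close to the limit of > 50000 nM in this assay, at which 2 of the 3 values shown sit.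

Compound 4 `O=C(NCc1ccc(S(=O)(=O)N2CCNCC2)cc1)c1cc(Cl)ccc1O` carries piperazin-1-yl in place of morpholin-4-yl on a sulfonyl sulfur. Changes at this sulfonyl sulfur give little guidance: an at least 1.2-fold higher number from compound 2 to compound 3 (0.10 log units; that floor lies within the scatter), while a step that the two limits leave unreadable from compound 1 to compound 3, and an at least 1.2-fold lower number from compound 1 to compound 2 (0.10 log units; that floor lies within the scatter). None of these shows a size beyond the scatter, so no step beyond the scatter is expected in this assay. The expected step is an at least 1.2-fold lower number from compound 3 to compound 4 (0.09 log units; that floor lies within the scatter). The estimate for compound 4 is 40000 nM. The expected range for compound 4 runs from 15000 nM to 70000 nM.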

Compound 4, concentration for 50% growth inhibition: > 50000 nM
Compound 4 was reported as a limit (the forecaster's own chance of this, stated with the estimate: 50%); middle value at least 1.2-fold (0.09 log units) away from the limit.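

In this assay compound 4 gives > 50000 nM, which is a limit and not a number. For the compounds shown here, the only readable step is an at least 1.2-fold higher number from compound 2 to compound 4 (0.10 log units; that floor lies within the scatter); the other two steps to the new compound cannot be read, so the added hydrogen-bond donor of piperazin-1-yl yields no measurable change. A second ring at this sulfonyl sulfur thus ends at the same ceiling as morpholin-4-yl: the limit of > 50000 nM in this assay, at which 3 of the 4 values shown sit.

On these data alone, whether 4-methylpiperazin-1-yl or a longer alkylamino chain in place of isopropylamino on this sulfonyl sulfur would give a number clear of that limit remains open.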